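The source may report more compounds than this note shows. Statements on the series, on what has been measured and on what is new or still open speak of the compounds shown alone.

Measured so far:
compound 1 `Cc1ccccc1-c1cc(C#Cc2ccc(CCC(=O)O)cc2)ccn1` — compound 1 gives 92%
compound 2 `O=C(O)CCc1ccc(C#Cc2ccncc2)cc1` — compound 2 gives 100%

Among the measured compounds shown here, in an in vitro functional assay on 1321-N1 cells for agonist activity at Free fatty acid receptor 1 (Homo sapiens), read by fluorescence, spectrophotometry and calcium flux (a lower number here means a smaller maximal response, a higher number a larger maximal response), compound 2 gives 100% and compound 1 gives 92%; the only measured step, a number 8 percentage points higher from compound 1 to compound 2 (within the scatter), shows the two as indistinguishable, so neither can be set above the other.

The next compound, compound 3 `O=C(O)CCc1ccc(C#Cc2ccccn2)cc1`, differs from compound 2 in one place: pyridin-2-yl in place of pyridin-4-yl on a triple-bonded carbon.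

For the measured compounds named here, no measured step concerns this kind of change; the one step on record, a number 8 percentage points higher from compound 1 to compound 2 (within the scatter), is a hydrogen in place of 2-methylphenyl on an aromatic carbon and does not bear on where the nitrogen sits in the ring on the triple-bonded carbon. With both measured compounds giving large maximal responses, the expectation for this assay is that compound 3 remains near them, with the step of a number 10 percentage points lower from compound 2 to compound 3 (within the scatter) expected to fall at or within the scatter. Compound 3 is estimated at 90%, with a range from 65% to 105%.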

Compound 3, largest response reached (reported as efficacy), in percent of the reference or control that the assay uses: 98%
Estimate against measurement, compound 3: 8 percentage points below, and the stated range covers the measured number.
By their numbers in this assay, from the lowest: compounds 1, 3 and 2 (each within the scatter of the next).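

In this assay the change reads as a number 2 percentage points lower from compound 2 to compound 3 (within the scatter) and so pyridin-2-yl and pyridin-4-yl on the triple-bonded carbon cannot be told apart by largest response. Among the compounds shown here, this is the first change at this place, and moving the ring nitrogen here, with the group's atoms and its hydrogen-bond donor and acceptor counts unchanged, leaves no readable mark on this read-out. No available measurement accounts for this result or ties it to a property of either group.

Still open is whether pyridin-3-yl or phenyl on the triple-bonded carbon would also give a response within the scatter of these compounds. Also open, from the compounds shown here alone, is whether the two pyridinyl compounds differ in the concentration needed to reach that response.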